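Trading a Cyclopropyl for a Phenyl on the Amine Arm

The compounds below may be only part of what the source reports. "The series", "measured", "known", "first", "only" and "open" are said of these compounds alone.

Going by the values given here, in an assay on cells for displacement of a labelled ligand from corticotropin-releasing factor receptor 1 (Homo sapiens), with a stated time of 100 min (a higher number here means a weaker inhibitor, a lower number a stronger inhibitor), compound 1 `CCN(Cc1c(C(F)(F)F)nc2n(-c3c(C)cc(C)cc3C)c(Cl)cn12)CC1CC1` gives 9 nM, the lowest of the three numbers measured so far. Compound 2 `C=C(C)CN(CC)Cc1c(C(F)(F)F)nc2n(-c3c(C)cc(C)cc3C)c(Cl)cn12` gives 67 nM, and compound 3 `CCCCN(Cc1ccccc1)Cc1c(C(F)(F)F)nc2n(-c3c(C)cc(C)cc3C)c(Cl)cn12` gives 130 nM. Among the compounds with values here, the only single-change step among them, a 7.4-fold higher number from compound 1 to compound 2 (0.87 log units; beyond the scatter), shows that swapping the cyclopropyl on the amine arm for another small group weakens binding by a modest but clear amount.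

Compound 4 `CCN(Cc1ccccc1)Cc1c(C(F)(F)F)nc2n(-c3c(C)cc(C)cc3C)c(Cl)cn12` differs from compound 1 in one place: phenyl in place of cyclopropyl on a saturated chain carbon bound to an amine nitrogen. Within the data shown here, no measured pair shows exactly this change. The step from compound 1 to compound 2 suggests that leaving the cyclopropyl costs potency, and compound 3, which also carries the benzyl group but differs from compound 4 in one further place, sits well above compound 1. Compound 4 is therefore expected to lose ground in this assay, with a step of about a 6.7-fold higher number from compound 1 to compound 4 (0.82 log units; beyond the scatter) in the weaker direction. For compound 4 the estimate is 60 nM, with a likely range from 20 nM to 200 nM.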

Compound 4, inhibition constant: 350 nM
Beside the measured number, compound 4's estimate is 5.8-fold (0.77 log units) below it; measured number above the stated range.
By their numbers in this assay, from the lowest: compound 1; then compounds 2 and 3 (each within the scatter of the next); then compound 4.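

In this assay, phenyl on this carbon is a far poorer partner for the amine than cyclopropyl, with a 39-fold higher number from compound 1 to compound 4 (1.59 log units; beyond the scatter) marking a large loss. The damage is not just a matter of leaving the cyclopropyl, since replacing the 1-methylethenyl group with phenyl still gives a 5.2-fold higher number from compound 2 to compound 4 (0.72 log units; beyond the scatter) and the loss continues beyond that small group. The far end of the other amine arm also counts when the benzyl group is present: hydrogen in place of ethyl on a saturated chain carbon, two bonds along the chain from an amine nitrogen, gives a 2.7-fold higher number from compound 3 to compound 4 (0.43 log units; beyond the scatter) and so a weaker binder.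

Still open, on these data alone, is whether a cyclohexyl group on this carbon, a six-carbon ring that is not aromatic, would fare as badly as phenyl. Nothing available gives a reason for these losses.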